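Swapping the Group on a Double-Bonded Nitrogen

The source may report more compounds than this note shows. Statements on the series, on what has been measured and on what is new or still open speak of the compounds shown alone.

In a functional assay on HepG2 cells (Homo sapiens) for cytotoxicity, read by sulforhodamine B assay, with a stated time of 24 h (a lower number here means a stronger inhibitor, a higher number a weaker inhibitor), compound 1 `Cc1ccc(S(=O)(=O)N/N=C2\C(=O)Nc3ccc(S(=O)(=O)N4CCOCC4)cc32)cc1` gives 24700 nM, compound 2 `CC(=O)N/N=C1\C(=O)Nc2ccc(S(=O)(=O)N3CCOCC3)cc21` gives 27500 nM and compound 3 `O=C1Nc2ccc(S(=O)(=O)N3CCOCC3)cc2/C1=N/c1ccc(C(=O)O)cc1` gives 23100 nM. Compound 3 thus lies within the scatter of both others. Compound 4 `O=C1Nc2ccc(S(=O)(=O)N3CCOCC3)cc2/C1=N/NS(=O)(=O)c1ccccc1` has (phenylsulfonyl)amino in place of 4-carboxyphenyl on a double-bonded nitrogen. For the measured compounds named here, two measured steps bear on this change, a 1.1-fold higher number from compound 1 to compound 2 (0.05 log units; within the scatter) and a 1.2-fold lower number from compound 2 to compound 3 (0.08 log units; within the scatter), and each stays within the scatter. Compound 1 also carries a sulfonyl group, (4-methylphenyl)sulfonyl, on an amine nitrogen. No shift beyond the scatter is therefore expected in this assay, in either direction. The expected change is small, a 1.0-fold higher number from compound 3 to compound 4 (0.02 log units; within the scatter). For compound 4 the estimate is 24000 nM, with an expected range of 12000 nM to 48000 nM.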

Compound 4, half-maximal inhibitory concentration: 23900 nM
Beside the measured number, compound 4's estimate is 1.0-fold (0.00 log units) above it; measured number inside the range.
By their numbers in this assay, from the lowest: compounds 3, 4, 1 and 2 (each within the scatter of the next).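

In this assay the exchange of 4-carboxyphenyl for (phenylsulfonyl)amino on the double-bonded nitrogen gives a 1.0-fold higher number from compound 3 to compound 4 (0.01 log units; within the scatter) and stays within the scatter, so this position tolerates either group here. Phenylsulfonyl in place of acetyl on an amine nitrogen gives a 1.2-fold lower number from compound 2 to compound 4 (0.06 log units; within the scatter) and hydrogen in place of methyl on an aromatic carbon gives a 1.0-fold lower number from compound 1 to compound 4 (0.01 log units; within the scatter) and neither step goes beyond the scatter. Nothing available explains this flatness. On these data alone, whether an amine or a longer chain on this nitrogen would shift the number beyond the scatter remains open.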